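Purine series on EOL1 cells: hydroxy to chloro swap

The source may hold more compounds than are shown below. What is called first, only, known or untested is meant among the compounds shown, and "the series" means these compounds.

Measured so far:
compound 1 `CCCCCCn1cnc2c(Nc3ccc(O)cc3)nc(N[C@H]3CC[C@H](N)CC3)nc21` — 190 nM
compound 2 `CC(C)CCn1cnc2c(Nc3ccccc3)nc(N[C@H]3CC[C@H](N)CC3)nc21` — 10 nM
compound 3 `CC(C)=CCn1cnc2c(Nc3cccc(Cl)c3)nc(N[C@H]3CC[C@H](N)CC3)nc21` — 80 nM

Three compounds of the shared core have been run in a functional assay on EOL1 cells (Homo sapiens) for inhibition, read by fluorescence, with a stated time of 72 h; a higher number here means a weaker inhibitor of growth, a lower number a stronger inhibitor of growth. Compound 1 gives the highest number of the three, 190 nM. Its nearest neighbour is compound 3 at 80 nM, a gap beyond the scatter, and compound 2 lies furthest away at 10 nM, also beyond the scatter. Compound 1 is therefore the weakest growth inhibitor among the three measured.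

Compound 4 `CCCCCCn1cnc2c(Nc3ccc(Cl)cc3)nc(N[C@H]3CC[C@H](N)CC3)nc21` is not yet measured. It differs from compound 1 in one place: chloro in place of hydroxy on an aromatic carbon. The change sits on a six-membered aromatic ring of carbon only, para to a large group; the hexyl chain and the aminocyclohexyl group are unchanged.

For the measured compounds named here, no measured pair shows this exact exchange. Compound 3 carries chloro and gives 80 nM, a lower number than compound 1, though its chain also differs, so the comparison is indirect. The step from compound 1 to compound 4 is expected to be a moderate move toward a lower number, a 2.7-fold lower number from compound 1 to compound 4 (0.43 log units; beyond the scatter). For compound 4 the value in this assay is estimated at 70 nM, within 20 nM to 250 nM.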

Compound 4, concentration for 50% growth inhibition: 440 nM
Compound 4: the middle estimate sits 6.3-fold (0.80 log units) below what was measured; the whole stated range lies below it.
By their numbers in this assay, from the lowest: compound 2; then compound 3; then compound 1; then compound 4.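

With the hexyl chain and the aminocyclohexyl group unchanged, chloro in place of hydroxy gives a 2.3-fold higher number from compound 1 to compound 4 (0.36 log units; beyond the scatter) in this assay, the only direct reading of this exchange among the compounds shown. At this aromatic carbon, para to a large group, compound 1 with hydroxy is therefore the stronger growth inhibitor of the pair, and with the hexyl chain in place chloro brings no gain over hydroxy. The exchange removes the hydrogen-bond donor and acceptor counted for hydroxy, but nothing available links those counts, or any other feature of the change, to the rise in the number.

Going by these compounds, whether an amine, a methoxy group or fluoro at this carbon would fall nearer hydroxy or chloro remains open. Also open, on these data alone, is whether the exchange runs in the same direction with a shorter chain in place of hexyl.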